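The compounds below may be only part of what the source reports. "The series", "measured", "known", "first", "only" and "open" are said of these compounds alone.

In a functional assay on SW480 cells (Homo sapiens) for cytotoxicity, read by sulforhodamine B assay, with a stated time of 48 h (on this read-out lower numbers stand for stronger inhibition and higher numbers for weaker inhibition), three compounds have been measured so far:

compound 1 `COc1cc(/C=C/C(=O)c2ccc(N)c(-c3ccc(F)cc3)c2)cc(Br)c1O` gives 22900 nM
compound 2 `COc1cc(/C=C/C(=O)c2ccc(N)c(-c3ccc(F)cc3)c2)ccc1O` gives 8350 nM
compound 3 `COc1ccc(/C=C/C(=O)c2ccc(N)c(-c3ccc(F)cc3)c2)cc1OC` gives 6640 nM

Compound 2 holds the second highest of these three numbers. Compound 3 is its nearest neighbour and compound 1 its furthest. The next compound to be tested is compound 4 `Nc1ccc(C(=O)/C=C/c2ccc(O)c(F)c2)cc1-c1ccc(F)cc1`, which departs from compound 2 as follows: fluoro in place of methoxy on an aromatic carbon. Put another way, the 4-hydroxy-3-methoxyphenyl group of compound 2 becomes a 3-fluoro-4-hydroxyphenyl group in compound 4.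

Going by the values given here, two measured steps bear on this change, and neither replaces the methoxy group itself. The first changes the neighbouring hydroxy group and shows a 1.3-fold lower number from compound 2 to compound 3 (0.10 log units; within the scatter). Among the compounds with values here, the second is the only measured step that involves a halogen, and it shows a 2.7-fold lower number from compound 1 to compound 2 (0.44 log units; beyond the scatter). That step concerns bromo rather than fluoro, so it serves only as a rough upper guide to size. Compound 4 keeps the hydroxy group and carries a halogen, as compound 1 does, which leans the expectation slightly towards a higher number. In this assay the expected step is a 1.3-fold higher number from compound 2 to compound 4 (0.12 log units; within the scatter). For compound 4 the estimated value is 11000 nM, with an expected range from 4500 nM to 25000 nM.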

Compound 4, half-maximal inhibitory concentration: 31700 nM
Compound 4: the middle estimate sits 2.9-fold (0.46 log units) below what was measured, outside the stated range (above it).
By their numbers in this assay, from the lowest: compounds 3 and 2 (each within the scatter of the next); then compounds 1 and 4 (each within the scatter of the next).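

In this assay, this is the only step among the compounds shown that changes the methoxy group itself, and putting fluoro in its place gives a 3.8-fold higher number from compound 2 to compound 4 (0.58 log units; beyond the scatter), so inhibition of the cells is weaker. The earlier steps shown here altered the hydroxy group or removed bromo and left the methoxy group in place, whereas this one shows that the aromatic carbon ortho to a hydroxy group is not indifferent to what it carries: the exchange of methoxy for fluoro, with one heavy atom fewer and one hydrogen-bond acceptor fewer, moves the number beyond the scatter. Nothing available on these compounds explains why this exchange weakens inhibition.

The compounds shown leave open whether the weaker inhibition follows from losing the methoxy group or from bringing in fluoro, a question that plain hydrogen, a chloro group or an ethoxy group at the same carbon would help to settle. They also leave open whether the same step would hold with the neighbouring hydroxy group replaced by methoxy, as in a 3-fluoro-4-methoxyphenyl group.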